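The source may report more compounds than this note shows. Statements on the series, on what has been measured and on what is new or still open speak of the compounds shown alone.

Measured so far:
Compound 1 `O=S(=O)(Nc1cccc2c1CCCC2c1c[nH]cn1)C1CC1` gives < 10000 nM, a limit of the assay rather than a number.
Compound 2 `CCS(=O)(=O)Nc1cccc2c1CCCC2c1c[nH]cn1` gives 1320 nM.

In an assay on isolated protein (Cricetulus griseus) for binding affinity to Alpha-1B adrenergic receptor (Mesocricetus auratus), read by radioligand binding (on this read-out higher numbers stand for weaker inhibition and lower numbers for stronger inhibition), compound 2 stands at the only number shown. Compound 1 sits at a limit (the limit of < 10000 nM in this assay, at which 1 of the 2 values shown sits), so the step that the limit leaves unreadable from compound 1 to compound 2 cannot be read in size. Compound 3 `CN(C)S(=O)(=O)Nc1cccc2c1CCCC2c1c[nH]cn1` differs from compound 2 in one place: dimethylamino in place of ethyl on a sulfonyl sulfur. Among the compounds with values here, no measured step bears on this change, so nothing beyond the scatter is expected in this assay. Compound 3 is therefore estimated at 1500 nM, between 500 nM and 4500 nM, a step of a 1.1-fold higher number from compound 2 to compound 3 (0.06 log units; within the scatter) from compound 2.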

Compound 3, inhibition constant: < 10000 nM
Compound 3: no number, only a limit; the forecaster's own chance of this, stated with the estimate: 15%; the middle value does not contradict the limit.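

Compound 3 gives only a limit in this assay, so its steps from compound 1 and compound 2 cannot be read: the limit of < 10000 nM in this assay, at which 2 of the 3 values shown sit.

The compounds shown leave open whether dimethylamino in place of ethyl on a sulfonyl sulfur changes the binding affinity at all.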